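Swapping a Ring Substituent in a P2X7 Antagonist Series

The source may hold more compounds than are shown below. What is called first, only, known or untested is meant among the compounds shown, and "the series" means these compounds.

Compound 1, `CN1C(=O)C(C)(C)C[C@H]1C(=O)NCc1cccc(C(F)(F)F)c1Cl`: 25.1 nM
Compound 2, `CN1CCC(N2C[C@@H](C(=O)NCc3cccc(C(F)(F)F)c3Cl)N(C)C2=O)CC1`: 31.6 nM

Two measured compounds share an amide core carrying the same substituted benzyl group. In a functional assay on HEK293 cells for antagonist activity at P2X purinoceptor 7 (Homo sapiens) (on this read-out lower numbers stand for stronger inhibition and higher numbers for weaker inhibition), compound 1 gives 25.1 nM, and compound 2 gives 31.6 nM. Within the data shown here, compound 2 has the higher of the two numbers, but its only neighbour, compound 1, lies within the usual scatter of repeated measurements, so the two cannot be ranked against each other.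

Compound 3, `CN1C(=O)N(c2nccn2C)C[C@H]1C(=O)NCc1cccc(C(F)(F)F)c1Cl`, has not yet been measured. It differs from compound 2 in a single place: 1-methyl-1H-imidazol-2-yl in place of 1-methylpiperidin-4-yl on an amide-type nitrogen in a ring. Among the measured compounds shown here, no pair of measured compounds differs by this kind of change, so there is no measured step to lean on; the only guidance is that the two measured compounds, despite different cores, give numbers close to each other. The step from compound 2 to compound 3 is therefore expected to be small, a 1.3-fold higher number from compound 2 to compound 3 (0.10 log units; within the scatter), with no clear direction beyond the scatter. In this assay compound 3 is expected to give about 40 nM, most likely between 12 nM and 130 nM.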

Compound 3, half-maximal inhibitory concentration: 3.98 nM
Compound 3: the middle estimate sits 10-fold (1.00 log units) above what was measured; measured number outside the range, below it.
By their numbers in this assay, from the lowest: compound 3; then compounds 1 and 2 (each within the scatter of the next).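

The position on the amide-type nitrogen in the ring responds clearly to what it carries: in this assay, replacing 1-methylpiperidin-4-yl with 1-methyl-1H-imidazol-2-yl gives a 7.9-fold lower number from compound 2 to compound 3 (0.90 log units; beyond the scatter). Among these compounds, this is the first measured step at this position, and it shows that the group there can move the number by more than the usual scatter, which the two earlier compounds, with their different cores, could not show. The swap changes several things at once, since a six-membered non-aromatic ring gives way to a five-membered aromatic ring with a different number of hetero atoms and hydrogen-bond acceptors, and no measurement here shows which of these differences matters or why the number falls.

With a single step at this position, the compounds shown leave open whether the lower number belongs to aromatic rings in general or to this particular ring. A phenyl ring, a pyridine ring or an imidazole without its methyl group in the same place would help separate these possibilities.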